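Bromophenyl Gives Way to Dimethylphenyl on the Sulfur

This account rests on a few compounds, and the source may have more. Where it says the series, first, only, none or still open, it means among the compounds named here.

Compound 2 `Nc1ccccc1NC(=O)c1ccc(CSc2ccc(Br)cc2)cc1` gives 67.7% in a functional assay on HCT-116 cells (Homo sapiens) for inhibition, read by CCK-8 assay, with a stated time of 72 h, tested at 8 uM (on this read-out lower numbers stand for less inhibition of growth and higher numbers for more inhibition of growth at the one concentration tested), the highest of the three measured numbers. Compound 1 `Cc1ccc(SCc2ccc(/C=C/C(=O)Nc3ccccc3N)cc2)cc1` gives 4.93% and compound 3 `Nc1ccccc1NC(=O)/C=C/c1ccc(CSc2ccc(Cl)cc2)cc1` gives 3.27%, both far below compound 2. For the measured compounds named here, the only single-point step measured, a number 1.7 percentage points lower from compound 1 to compound 3 (within the scatter), lies within the scatter and merely shows that chloro in place of methyl on an aromatic carbon changes little. Compound 4 `Cc1cc(C)cc(SCc2ccc(C(=O)Nc3ccccc3N)cc2)c1` differs from compound 2 in one place: 3,5-dimethylphenyl in place of 4-bromophenyl on a sulfur. Going by the values given here, no measured step alters the group on a sulfur, so the data give only weak guidance, and since compound 4 keeps the core of compound 2, a moderate change is the most reasonable expectation. Compound 4 is therefore expected to show a modest step, a number 12.7 percentage points lower from compound 2 to compound 4 (beyond the scatter), rather than a collapse. The estimate for compound 4 is 55%, ranging from 30% to 75%.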

Compound 4, percent growth inhibition at one concentration: 72.9%
Estimate against measurement, compound 4: 17.9 percentage points below; the measured number falls inside the stated range.
By their numbers in this assay, from the lowest: compounds 3 and 1 (each within the scatter of the next); then compounds 2 and 4 (each within the scatter of the next).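

In this assay, 3,5-dimethylphenyl in place of 4-bromophenyl on a sulfur gives a number 5.2 percentage points higher from compound 2 to compound 4 (within the scatter). For the compounds shown here, this is the first measured change to the group on the sulfur, and it shows that this group can lose its bromine and gain two methyl groups without a step beyond the scatter. No measurement shown explains this result.

Still open, going by these compounds, is how a phenyl ring carrying an amine or a carboxylic acid would read on this sulfur. On these data alone, it is also open whether the same swap would hold on the core of compound 1.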